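Acetyl in Place of Cyano on a Shared Core

The compounds below may be only part of what the source reports. "The series", "measured", "known", "first", "only" and "open" are said of these compounds alone.

Of the compounds shown here, two built on one core have been measured in a functional assay for inhibition of nuclear factor NF-kappa-B complex (Homo sapiens); a higher number here means a weaker inhibitor, a lower number a stronger inhibitor. Compound 1 `COc1ccc2c(c1)OC(c1cc(OC)c(OC)c(OC)c1)C(C(=O)OC(C)C)=C2` gives 11800 nM. Compound 2 `COc1ccc2c(c1)OC(c1cc(OC)c(OC)c(OC)c1)C(C#N)=C2` gives 3400 nM, the lower of the two numbers; the step of a 3.5-fold lower number from compound 1 to compound 2 (0.54 log units; beyond the scatter) came from putting a cyano in place of the isopropoxycarbonyl on a double-bonded ring carbon. Compound 3 `COc1ccc2c(c1)OC(c1cc(OC)c(OC)c(OC)c1)C(C(C)=O)=C2` is not yet measured and differs from compound 2 by acetyl in place of cyano on a double-bonded ring carbon. For the measured compounds named here, only the step from compound 1 to compound 2 bears on this change, and it showed that exchanging the group at this position can move the number beyond the scatter. The acetyl carries a carbonyl, as the isopropoxycarbonyl did, though it is a smaller group, so a modest rise toward the number of compound 1 seems likely. Relative to compound 2, compound 3 is therefore expected to shift by a 1.8-fold higher number from compound 2 to compound 3 (0.25 log units; within the scatter), with an estimated value of 6000 nM and a range from 2500 nM to 15000 nM in this assay.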

Compound 3, half-maximal inhibitory concentration: 14100 nM
Compound 3: middle estimate off by 2.4-fold (0.37 log units), on the low side; the range from low to high includes it.
By their numbers in this assay, from the lowest: compound 2; then compounds 1 and 3 (each within the scatter of the next).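

In this assay, acetyl in place of cyano raises the number beyond the scatter (a 4.1-fold higher number from compound 2 to compound 3 (0.62 log units; beyond the scatter)), so a lower number at this double-bonded ring carbon does not follow from simply shortening the isopropoxycarbonyl to acetyl. Methyl in place of isopropoxy on the carbonyl carbon stays within the scatter (a 1.2-fold higher number from compound 1 to compound 3 (0.08 log units; within the scatter)), so the two carbonyl-bearing groups cannot be told apart here, and among these three compounds only the cyano of compound 2 stands apart. Nothing at hand explains why this position responds in this way.

The compounds shown leave open how a carboxylic acid, a primary amide or an aminomethyl group on this carbon would read, and whether any group goes below compound 2. They also leave open whether the cyano keeps its advantage when the methoxy groups on the shared core are changed.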